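Removing one fluorine from a difluoro compound

This account rests on a few compounds, and the source may have more. Where it says the series, first, only, none or still open, it means among the compounds named here.

Compounds measured so far:
compound 1, `O=C(/C=C1\CCc2c(F)cc(F)cc21)NC1CC1`, gives 38%
compound 2, `O=C(/C=C1\CCc2ccc(Br)cc21)NC1CC1`, gives 29%
compound 3, `O=C(/C=C1\CCc2cc(F)c(F)cc21)NC1CC1`, gives 30%

All three were tested in a functional assay on the whole organism with Rattus norvegicus as the target, at a dose of 20 mg/kg by the oral route; a lower number here means less inhibition, a higher number more inhibition at the dose given (going by the name of the read-out). Compound 3 holds the second highest of the three numbers, yet its neighbours sit close by: compound 2 lies within the usual scatter of it, and so does compound 1, the furthest of the three. On these numbers, then, nothing separates the three compounds with any confidence.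

The next compound, compound 4, `O=C(/C=C1\CCc2ccc(F)cc21)NC1CC1`, has not yet been measured. It differs from compound 3 in a single place: hydrogen in place of fluoro on an aromatic carbon. One of the two fluoro groups on the six-membered aromatic ring of the shared core is gone, and the ring keeps the other.

Within the data shown here, because the values of compounds 1, 2 and 3 all lie within the scatter of one another in this assay, there is no measured step to lean on for the size of such a change. The plain expectation is that the step of no change at the digits printed from compound 3 to compound 4 (within the scatter) stays within the scatter, with no direction favoured. Compound 4 is therefore estimated at 30%, with a range from 15% to 45%.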

Compound 4, a percentage reported as inhibition, in the whole organism at one dose (the size of the read-out at that dose, not a potency): 5%
Compound 4: middle estimate off by 25 percentage points, on the high side; measured number outside the range, below it.
By their numbers in this assay, from the lowest: compound 4; then compounds 2, 3 and 1 (each within the scatter of the next).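

The earlier compounds shown here all lay within the scatter of one another in this assay, so they gave no sign that this ring carbon mattered; here, hydrogen in place of fluoro on it gives a number 25 percentage points lower from compound 3 to compound 4 (beyond the scatter). The same change at a different carbon of the ring gives a number 33 percentage points lower from compound 1 to compound 4 (beyond the scatter), so compounds 1 and 3, which carry their second fluoro on different carbons, both stand clear of compound 4, which keeps only one fluoro. Compound 2 carries one halogen too, yet fluoro in place of its bromo gives a number 24 percentage points lower from compound 2 to compound 4 (beyond the scatter), so among these four compounds, the single fluoro of compound 4 is the one arrangement that stands apart, and no compound shown goes against this.

No measurement at hand says why the number falls at this step. Still open, from the compounds shown here alone, is whether a chloro, methyl or methoxy group on the carbon that loses its fluoro in compound 4 would match compound 3, and whether a different result would appear at other oral doses, since this read-out at one dose is not a potency.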